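A few compounds are considered here, and "the series" means these few. Any claim that something is new, unique, unknown or untested is made for them only; others in the source may bear on it.

Compound 1 `CCOC1c2cc(OCc3cc(C)cc(C)c3)c(OCc3cc(C)cc(C)c3)cc2CCN1C(=O)OC(C)(C)C`: > 20000 nM
Compound 2 `CC[C@@H]1CC(=O)C/C=C(/C)[C@H]2c3cc(OCc4ccccc4)c(OCc4ccccc4)cc3CCN12`: > 20000 nM
Compound 3 `CC[C@@H]1C[C@@H](O)C/C=C(/C)[C@H]2c3cc(OCc4ccccc4)c(OCc4ccccc4)cc3CCN12`: > 20000 nM

All three compounds were tested in a functional assay on MDA-MB-231 cells (Homo sapiens) for inhibition, read by MTT assay, with a stated time of 24 h; on this read-out higher numbers stand for weaker inhibition and lower numbers for stronger inhibition. Compound 1 gives > 20000 nM, which is a limit and not a number. Compound 2 gives > 20000 nM, also a limit. Compound 3 gives > 20000 nM, again a limit. Compound 1 therefore stands with the rest of the set, and the whole picture is the limit of > 20000 nM in this assay, at which 3 of the 3 values shown sit. Among the measured compounds shown here, no measured compound offers a number to compare against.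

Compound 4 `Cc1cc(C)cc(COc2cc3c(cc2OCc2cc(C)cc(C)c2)CN(C(=O)OC(C)(C)C)CC3)c1` differs from compound 1 in one place: hydrogen in place of ethoxy on a saturated ring carbon. Put simply, it has hydrogen in place of ethoxy on a saturated ring carbon, and the rest of the core of compound 1 is kept. For the measured compounds named here, no measured pair shows what this exchange does, so the expectation rests on compound 1 and its limit of > 20000 nM. The expected change, a step that the limit leaves unreadable from compound 1 to compound 4, is none beyond the usual scatter, in either direction. In this assay the estimate for compound 4 is 25000 nM, with an expected range from 10000 nM to 60000 nM.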

Compound 4, half-maximal inhibitory concentration: > 20000 nM
Compound 4: a limit, no number (the forecaster's own chance of this, stated with the estimate: 80%); the middle value does not contradict the limit.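

Compound 1 and compound 4 both end at a limit in this assay, so no step can be read for hydrogen in place of ethoxy on a saturated ring carbon. The compounds shown leave open what actual inhibition any of them has, since none gives a number: the limit of > 20000 nM in this assay, at which 4 of the 4 values shown sit.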